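From methyl to trifluoromethoxy on compound 2

A few compounds are considered here, and "the series" means these few. Any claim that something is new, unique, unknown or untested is made for them only; others in the source may bear on it.

Measured so far:
- compound 1 `CCN(CC)c1ccc2nc(-c3ccccc3OC(F)(F)F)[nH]c(=O)c2c1` gives 1710 nM
- compound 2 `Cc1ccc2nc(-c3ccccc3C)[nH]c(=O)c2c1` gives 11700 nM

These two numbers come from a functional assay on HCT-15 cells (Homo sapiens) for cytotoxicity, read by MTT assay, with a stated time of 2 days (a higher number here means a weaker inhibitor, a lower number a stronger inhibitor), and are all that is known so far. Compound 2 stands highest of the pair at 11700 nM and is therefore the weaker inhibitor, and its gap to compound 1 lies beyond the usual scatter.

The next compound is compound 3 `Cc1ccc2nc(-c3ccccc3OC(F)(F)F)[nH]c(=O)c2c1` and it is unmeasured. The change trifluoromethoxy in place of methyl on an aromatic carbon puts trifluoromethoxy in place of methyl on an aromatic carbon of a six-membered aromatic ring of carbon only, ortho to a large group.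

Among the measured compounds shown here, no pair of measured compounds shows this change alone, so any forecast is rough. Compound 1 also carries trifluoromethoxy and reads 1710 nM in this assay and this suggests a lower number for compound 3, though compound 1 has a second difference elsewhere on the core. The estimated change is a 2.3-fold lower number from compound 2 to compound 3 (0.37 log units; beyond the scatter) towards a stronger inhibitor, expected to lie only modestly beyond the scatter. Compound 3 is expected at 5000 nM with an estimated range of 1700 nM to 14000 nM here.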

Compound 3, half-maximal inhibitory concentration: 2790 nM
The estimate for compound 3 lay 1.8-fold (0.25 log units) above the measured number; the range from low to high includes it.
By their numbers in this assay, from the lowest: compounds 1 and 3 (each within the scatter of the next); then compound 2.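

In this assay the swap of trifluoromethoxy in place of methyl on an aromatic carbon, ortho to a large group, gives a 4.2-fold lower number from compound 2 to compound 3 (0.62 log units; beyond the scatter) and so yields a stronger inhibitor with the rest of the molecule unchanged, something the first two compounds could not show because they differ in more than one place. On the core, methyl in place of diethylamino gives a 1.6-fold higher number from compound 1 to compound 3 (0.21 log units; within the scatter) and so leaves no real difference between these two groups in this comparison, where both compounds carry trifluoromethoxy. Nothing measured on these compounds bears on the reason for either result.

On these data alone, it remains open whether a methoxy group or a chlorine atom on this same carbon would give a number nearer that of methyl or that of trifluoromethoxy, so the step cannot yet be tied to the oxygen or to the fluorine atoms. Also open, as far as these compounds go, is whether diethylamino and methyl on the core would still read alike with methyl rather than trifluoromethoxy on the aromatic ring.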